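Cyano in Place of Methoxy: Expected Binding of Compound 3

This account rests on a few compounds, and the source may have more. Where it says the series, first, only, none or still open, it means among the compounds named here.

Going by the values given here, compound 1 `COc1cncc(C2=CC3CC(C2)CN(C)C3)c1` gives 596 nM in an in vitro assay on SH-SY5Y cells for displacement of a labelled ligand from Neuronal acetylcholine receptor; alpha3/beta4 (Homo sapiens) (a higher number here means a weaker inhibitor, a lower number a stronger inhibitor), the lower of the two numbers known. Compound 2 `COc1cc(C2=CC3CC(C2)CN(C)C3)cnc1Cl` gives 1430 nM in this assay, and the step of a 2.4-fold higher number from compound 1 to compound 2 (0.38 log units; beyond the scatter) comes with chloro in place of hydrogen on an aromatic carbon. Compound 3 `CN1CC2C=C(c3cncc(C#N)c3)CC(C2)C1` differs from compound 1 by cyano in place of methoxy on an aromatic carbon. Among the compounds with values here, no measured step exchanges one group for another at this place, so the single known step is of a different kind and guides only weakly; a modest shift in either direction is plausible. Compound 3 is thus expected at about 800 nM, between 250 nM and 2500 nM, a step of a 1.3-fold higher number from compound 1 to compound 3 (0.13 log units; within the scatter).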

Compound 3, inhibition constant: 4500 nM
Estimate against measurement, compound 3: 5.6-fold (0.75 log units) below; the measured number lies above the stated range.
By their numbers in this assay, from the lowest: compound 1; then compound 2; then compound 3.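

In this assay, exchanging methoxy for cyano on this aromatic carbon gives a 7.6-fold higher number from compound 1 to compound 3 (0.88 log units; beyond the scatter). The position is therefore not indifferent to the group it carries, even though both groups have 2 heavy atoms and 1 hydrogen-bond acceptor. Nothing measured accounts for the shift.

The compounds shown leave open whether the higher number follows from losing methoxy or from gaining cyano. On these data alone, how a hydroxyl, an amine or a longer ether chain such as ethoxy would read at this place also remains open.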